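Thiophene for methoxyphenyl: a stability step with no readable anchor

The source may report more compounds than this note shows. Statements on the series, on what has been measured and on what is new or still open speak of the compounds shown alone.

Compound 1 `COc1cccc(CCOc2ccc(-c3c(C)nc(C)c([C@H](OC(C)(C)C)C(=O)O)c3N3CCC(C)(C)CC3)cc2)c1`: > 2 h
Compound 2 `Cc1nc(C)c([C@H](OC(C)(C)C)C(=O)O)c(N2CCC(C)(C)CC2)c1-c1ccc(OCCc2ccc(F)c(F)c2)cc1`: > 2 h
Compound 3 `Cc1nc(C)c([C@H](OC(C)(C)C)C(=O)O)c(N2CCC(C)(C)CC2)c1-c1ccc(OCCc2cc(F)c(F)cc2F)cc1`: > 2 h

In an ADME assay on microsomes from liver (Homo sapiens) for metabolic stability, read by LC-MS, tested at 0.5 uM (on this read-out lower numbers stand for a shorter-lived compound and higher numbers for a longer-lived compound), compound 1 gives > 2 h, which is a limit of the assay rather than a number. Compound 2 likewise sits at a limit. So does compound 3. Because of the limit of > 2 h in this assay, at which 3 of the 3 values shown sit, the steps a step that the two limits leave unreadable from compound 1 to compound 2 and a step that the two limits leave unreadable from compound 1 to compound 3 cannot be sized, and neither can a step that the two limits leave unreadable from compound 2 to compound 3. Compound 4 `Cc1ccc(CCOc2ccc(-c3c(C)nc(C)c([C@H](OC(C)(C)C)C(=O)O)c3N3CCC(C)(C)CC3)cc2)s1` differs from compound 1 by 5-methylthiophen-2-yl in place of 3-methoxyphenyl on a saturated chain carbon, two bonds along the chain from an oxygen on an aromatic ring. The measured steps involve other groups entering at the same place and all stay at the limit, so no direction can be read for the new change in this assay. Compound 4 is expected to give 2.5 h, between 1 h and 6 h, and the step that the limit leaves unreadable from compound 1 to compound 4 is estimated to lie within the scatter.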

Compound 4, half-life: > 2 h
Compound 4 ended at the assay's limit (the forecaster's own chance of this, stated with the estimate: 65%); the middle value does not contradict the limit.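

No step from compound 4 to compound 1, compound 2 or compound 3 can be read, because all of them stand at the same limit: the limit of > 2 h in this assay, at which 4 of the 4 values shown sit.

Left open is how long each compound actually lasts, and so whether 5-methylthiophen-2-yl and the groups it replaces differ at all.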